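The compounds below may be only part of what the source reports. "The series", "measured", "known", "first", "only" and "open" are said of these compounds alone.

Compound 1 `COc1cc(-c2cc(/C=C/C(=O)c3ccc(N)cc3)[nH]n2)cc(OC)c1OC`: -66%
Compound 2 `COc1ccc(C(=O)/C=C/c2cc(-c3cc(OC)c(OC)c(OC)c3)n[nH]2)cc1OC`: -71%

In a functional assay on OVCAR-5 cells (Homo sapiens) for cytotoxicity, read by sulforhodamine B assay, with a stated time of 48 h, tested at 100 uM (a lower number here means a stronger effect, a higher number a weaker effect of the compound at the concentration tested), compound 2 gives the lowest of the two numbers, and its nearest neighbour is compound 1, the step being a number 5 percentage points lower from compound 1 to compound 2 (within the scatter). Compound 3 `COc1cc(C(=O)/C=C/c2cc(-c3cc(OC)c(OC)c(OC)c3)n[nH]2)cc(OC)c1OC` differs from compound 2 by methoxy in place of hydrogen on an aromatic carbon. Going by the values given here, only one measured step exists, a number 5 percentage points lower from compound 1 to compound 2 (within the scatter), and it changed the group on the carbonyl carbon, not an aromatic carbon ortho to a methoxy group, so it bears only loosely here; no measured step adds a methoxy. No step beyond the scatter is therefore expected, a number 1 percentage points higher from compound 2 to compound 3 (within the scatter). Compound 3 is estimated at -70%, in the range -85% to -50%.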

Compound 3, a percentage reported as activity, at one concentration (the size of the read-out at that concentration, not a potency): -72%
Beside the measured number, compound 3's estimate is 2 percentage points above it, within the range that was stated.
By their numbers in this assay, from the lowest: compounds 3, 2 and 1 (each within the scatter of the next).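

Putting methoxy in place of hydrogen on this aromatic carbon, ortho to a methoxy group, gives a number 1 percentage points lower from compound 2 to compound 3 (within the scatter) in this assay. Going by these compounds alone, this is the first measured step at this position, and at this single concentration compound 2 and compound 3 cannot be told apart. Nothing measured here offers an explanation for this result. Open, from the compounds shown here alone, is whether another group at this position, such as an amine or a carboxylic acid, would give a step beyond the scatter. Also open, going by these compounds, is whether compound 2 and compound 3 would separate at lower concentrations.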